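The compounds below may be only part of what the source reports. "The series", "measured", "known", "first", "only" and "open" are said of these compounds alone.

Within the data shown here, compound 3, with the structure `COc1nn2cc(-c3cc4ccccc4o3)nc2s1`, is the one member of this set that comes with a number: in an assay for antagonist activity at proteinase-activated receptor 4 (Homo sapiens), with stated times of 5 min, 50 s and 15 min, in the presence of a further agent that is not named here (a higher number here means a weaker inhibitor, a lower number a stronger inhibitor), compound 3 gives 240 nM. Its two companions, compound 1 `c1ccc(Sc2nn3cc(-c4cc5ccccc5o4)nc3s2)cc1` and compound 2 `CCSc1nn2cc(-c3cc4ccccc4o3)nc2s1`, share the same core and differ from it only in the group on the five-membered ring, yet no number was reported for either of them: in this assay compound 1 gives "not determined" (no result reported). In this assay compound 2 gives "not determined" (no result reported). Compound 3 therefore stands alone and no comparison within the measured compounds can be drawn. The step now followed leads to compound 4 `Cc1nn2cc(-c3cc4ccccc4o3)nc2s1`, where the change is methyl in place of methoxy on an aromatic carbon, the group sitting on an aromatic carbon of a five-membered aromatic ring with two nitrogens and one sulfur, part of a fused system of two rings. Among the measured compounds shown here, since no step between measured compounds is available, the expectation has to rest on compound 3 alone: a change of this modest size is expected to move the result little, most likely staying within or just beyond the usual scatter, with a slight lean toward a weaker value, so that the step from compound 3 to compound 4 is estimated at a 1.5-fold higher number from compound 3 to compound 4 (0.16 log units; within the scatter). Compound 4 is therefore expected to give about 350 nM in this assay, with a plausible range from 120 nM to 1000 nM.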

Compound 4, half-maximal inhibitory concentration: > 30000 nM
Compound 4 was reported as a limit (the forecaster's own chance of this, stated with the estimate: 10%); middle value at least 85-fold (1.93 log units) from the limit.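

Swapping methoxy for methyl on this aromatic carbon, next to the ring nitrogen and next to the ring sulfur, gives an at least 120-fold higher number from compound 3 to compound 4 (2.09 log units; beyond the scatter), which is the first readable evidence that the result in this assay depends strongly on the group at this position. Such a small exchange, with the rest of the structure unchanged, is enough to take the compound from a measured value to the end of the assay's range, something that compound 3 alone, as the only compound with a number, could not show. Compound 4 gives > 30000 nM, and this is a limit of the assay and not a number, so the true size of the step stays unknown: the limit of > 30000 nM in this assay, at which 1 of the 4 values shown sits.

From the compounds shown here alone, compound 1 and compound 2 carry no number, so steps involving their sulfur-linked groups cannot be read, and it remains open whether the oxygen atom of methoxy is what matters or whether another oxygen-linked group would do as well. The compounds shown also leave open how an ethoxy group, a hydroxyl or an amine at this position would read in this assay.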